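The source may hold more compounds than are shown below. What is called first, only, known or untested is meant among the compounds shown, and "the series" means these compounds.

In a functional assay on HL-60 cells (Homo sapiens) for inhibition, read by CCK-8 assay, with a stated time of 48 h (a higher number here means a weaker inhibitor, a lower number a stronger inhibitor), compound 3 (`COc1ccc(Oc2ccccc2-c2ccsc2S(=O)(=O)N2CCN(C(=S)Nc3ccc(Cl)cc3)CC2)cc1OC`) gives > 50000 nM, which is a limit of the assay and not a number. Compound 3 thus stands at the limit of > 50000 nM in this assay, at which 1 of the 3 values shown sits. Compound 4 (`O=S(=O)(c1sccc1-c1ccccc1Oc1ccc(O)c(O)c1)N1CCN(C(=S)Nc2ccc(Cl)cc2)CC1`) differs from it in one place: 3,4-dihydroxyphenyl in place of 3,4-dimethoxyphenyl on an oxygen on an aromatic ring. In words, 3,4-dihydroxyphenyl stands in place of 3,4-dimethoxyphenyl on an oxygen on an aromatic ring.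

Among the compounds with values here, no measured step covers this change directly. Within the data shown here, the only measured step, a 1.1-fold higher number from compound 1 to compound 2 (0.04 log units; within the scatter), lies within the scatter and leaves the changed group untouched, so it gives no size for this change. The indirect evidence comes from two compounds that already carry 3,4-dihydroxyphenyl but differ from compound 4 elsewhere in the structure. Compound 1 (`O=C(Nc1cccc([N+](=O)[O-])c1)N1CCN(S(=O)(=O)c2sccc2-c2ccccc2Oc2ccc(O)c(O)c2)CC1`) gives 4500 nM and compound 2 (`O=C(Nc1ccc([N+](=O)[O-])cc1)N1CCN(S(=O)(=O)c2sccc2-c2ccccc2Oc2ccc(O)c(O)c2)CC1`) gives 4900 nM, and these values lead to the expectation of a large move towards a lower number, meaning a stronger inhibitor. Those other structural differences keep the expectation loose. The expected size of the move is an at least 8.3-fold lower number from compound 3 to compound 4 (0.92 log units; beyond the scatter). For compound 4 the estimated value is 6000 nM, with an expected range from 2000 nM to 25000 nM.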

Compound 4, half-maximal inhibitory concentration: 5500 nM
For compound 4 the middle estimate is 1.1-fold (0.04 log units) above the measured one, and the stated range covers the measured number.
By their numbers in this assay, from the lowest: compounds 1, 2 and 4 (each within the scatter of the next). At a limit, above all of these: compound 3.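

Read in this assay, the exchange of 3,4-dimethoxyphenyl for 3,4-dihydroxyphenyl on an oxygen on an aromatic ring now has a direct measure, and it points towards a stronger inhibitor (an at least 9.0-fold lower number from compound 3 to compound 4 (0.95 log units; beyond the scatter)). That size is only a lower bound, since the value of compound 3 is a limit of the assay and not a number: the limit of > 50000 nM in this assay, at which 1 of the 4 values shown sits. The result also shows that, with 3,4-dihydroxyphenyl in place, a different group on the amine nitrogen in a ring, the chlorine- and sulfur-bearing one of compound 4 against the larger nitro-bearing ones of the other two, leaves the values within the scatter of each other (a 1.2-fold higher number from compound 1 to compound 4 (0.09 log units; within the scatter)) (a 1.1-fold higher number from compound 2 to compound 4 (0.05 log units; within the scatter)).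

As far as these compounds go, how far the true value of compound 3 lies from the limit stays open, and so does the full size of the step, and whether a 3,4-dimethoxyphenyl group would cost as much with the nitro-bearing groups on that nitrogen. Also open, from the compounds shown here alone, is whether a single hydroxyl, a single methoxy or an amine on the same aromatic ring would give values like that of compound 4 or like the limit of compound 3.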